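Weighing a New Aryl Amide Against Compound 3

This account rests on a few compounds, and the source may have more. Where it says the series, first, only, none or still open, it means among the compounds named here.

Measured in a functional assay on HT-29 cells (Homo sapiens) for cytotoxicity, read by MTT assay, with a stated time of 72 h; on this read-out lower numbers stand for stronger inhibition and higher numbers for weaker inhibition:
- compound 1 `O=C(CN1CCN(c2nnc(Cc3ccccc3)c3ccccc23)CC1)Nc1ccc(F)c(F)c1`: 9510 nM
- compound 2 `Cc1ccccc1NC(=O)CN1CCN(c2nnc(Cc3ccccc3)c3ccccc23)CC1`: 113000 nM
- compound 3 `Cc1cccc(Cl)c1NC(=O)CN1CCN(c2nnc(Cc3ccccc3)c3ccccc23)CC1`: 53600 nM

Among these three numbers, compound 3 stands second highest. The change to compound 4 `O=C(CN1CCN(c2nnc(Cc3ccccc3)c3ccccc23)CC1)Nc1cc(C(F)(F)F)ccc1Cl` is 2-chloro-5-(trifluoromethyl)phenyl in place of 2-chloro-6-methylphenyl on an amide-type nitrogen. Going by the values given here, two measured steps bear on it. The first is a 5.6-fold higher number from compound 1 to compound 3 (0.75 log units; beyond the scatter), where 2-chloro-6-methylphenyl replaces 3,4-difluorophenyl. The second is a 2.1-fold lower number from compound 2 to compound 3 (0.32 log units; beyond the scatter), where chloro replaces hydrogen. Among the compounds with values here, compound 1, the only measured compound without a methyl group, has the lowest number, but no measured compound carries trifluoromethyl. A modest step towards a lower number is therefore expected in this assay, with real uncertainty. The expected change is a 2.7-fold lower number from compound 3 to compound 4 (0.43 log units; beyond the scatter). Compound 4 is estimated at 20000 nM, within a range of 6000 nM to 60000 nM.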

Compound 4, half-maximal inhibitory concentration: 66800 nM
Beside the measured number, compound 4's estimate is 3.3-fold (0.52 log units) below it; measured number above the stated range.
By their numbers in this assay, from the lowest: compound 1; then compounds 3, 4 and 2 (each within the scatter of the next, the first and the last beyond it).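

In this assay compound 4, the only one carrying trifluoromethyl, stays within the scatter of both its neighbours (a 1.2-fold higher number from compound 3 to compound 4 (0.10 log units; within the scatter); a 1.7-fold lower number from compound 2 to compound 4 (0.23 log units; within the scatter)), so this change on the amide-type nitrogen does not separate it from compound 3 or compound 2. The gap to the 3,4-difluorophenyl amide remains beyond the scatter (a 7.0-fold higher number from compound 1 to compound 4 (0.85 log units; beyond the scatter)), and compound 1 keeps the lowest number of the four. No evidence given here accounts for this result. From the compounds shown here alone, whether a methoxyphenyl or a pyridine ring on this nitrogen would come closer to compound 1 stays open.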